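Diethylamino for dimethylamino on two related cores

The source may report more compounds than this note shows. Statements on the series, on what has been measured and on what is new or still open speak of the compounds shown alone.

Three compounds of this set have been examined in an ADME assay on HEK293 cells (Homo sapiens) for cytotoxicity, read by MTT assay, with a stated time of 48 h; a higher number here means a weaker inhibitor, a lower number a stronger inhibitor. Compound 1 `CN(C)CCn1c(N)c(-c2nc3ccccc3[nH]2)c2nc(C#N)c(C#N)nc21` gives 9730 nM there. Compound 2 `CCN(CC)CCn1c(N)c(-c2nc3ccccc3[nH]2)c2nc(C#N)c(C#N)nc21`, which carries diethylamino in place of dimethylamino on a saturated chain carbon, two bonds along the chain from an aromatic nitrogen, gives 12200 nM. For the measured compounds named here, the step of a 1.3-fold higher number from compound 1 to compound 2 (0.10 log units; within the scatter) is the only one between measured compounds that differ in a single place. Compound 3 `CN(C)CCCn1c(N)c(-c2nc3ccccc3n2C)c2nc(C#N)c(C#N)nc21`, built on a different core, gives 8410 nM in this assay; how its core differs from that of compound 1 is not broken down here.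

Compound 4 `CCN(CC)CCCn1c(N)c(-c2nc3ccccc3n2C)c2nc(C#N)c(C#N)nc21` has not yet been measured. It carries diethylamino in place of dimethylamino on a saturated chain carbon, three bonds along the chain from an aromatic nitrogen. Going by the values given here, this is the same kind of change as the one from compound 1 to compound 2, but the place is not identical: there the amine sits two bonds along the chain from the aromatic nitrogen, here three bonds along the chain. The expectation for compound 4 rests on compound 1 and compound 2, because a 1.3-fold higher number from compound 1 to compound 2 (0.10 log units; within the scatter) was within the scatter. The step is therefore expected to be a 1.2-fold higher number from compound 3 to compound 4 (0.10 log units; within the scatter) in this assay. Compound 4 is estimated to give 10500 nM, with a range from 6000 nM to 19000 nM.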

Compound 4, half-maximal inhibitory concentration: 7240 nM
Estimate against measurement, compound 4: 1.5-fold (0.16 log units) above; measured number inside the range.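

In this assay diethylamino in place of dimethylamino, on a saturated chain carbon three bonds along the chain from an aromatic nitrogen, gives a 1.2-fold lower number from compound 3 to compound 4 (0.07 log units; within the scatter) and this step lies within the scatter. Neither this step nor the earlier one can be told apart from no change, so the pair does not show that the swap has any effect of its own, and the core and the chain differ together between the two pairs. What it does show is that the swap reads alike on these two cores, with no sign that the core alters its outcome: the same change on two cores in this assay, a 1.3-fold higher number (0.10 log units; within the scatter) from compound 1 to compound 2 and a 1.2-fold lower number (0.07 log units; within the scatter) from compound 3 to compound 4, 1.5-fold (0.16 log units) apart, within the scatter of two such steps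

The compounds shown leave open whether a cyclic amine such as piperidine or morpholine, or a longer chain, would move the number beyond the scatter. They also leave open how the swap reads when only the core differs and the chain is held the same.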